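Cyclopropane carboxylate in place of the gem-dimethyl acid

The source may hold more compounds than are shown below. What is called first, only, known or untested is meant among the compounds shown, and "the series" means these compounds.

Compound 3 `Cc1cc(OC[C@@H]2CN(C)c3ccccc3O2)cc(C)c1C(=O)Nc1cc(C(C)(C)C(=O)O)ccc1Cl` gives 0.7 nM in a functional assay on CHO cells for antagonist activity at prostaglandin D2 receptor (Mus musculus), read by cAMP accumulation and immunoassay, with a stated time of 10 min (a lower number here means a stronger inhibitor, a higher number a weaker inhibitor), the lowest number among the three measured. Compound 1 `Cc1cc(OC[C@@H]2CN(C)c3ccccc3O2)cc(C)c1C(=O)Nc1cc(CC(=O)O)ccc1Cl` gives 7.6 nM and compound 2 `Cc1cc(C(=O)Nc2cc(C(C)(C)C(=O)O)ccc2Cl)c(C)cc1OC[C@@H]1CN(C)c2ccccc2O1` gives 43 nM. The step of an 11-fold lower number from compound 1 to compound 3 (1.04 log units; beyond the scatter) shows that branching the acid-bearing carbon lowers the number strongly. Compound 4 `Cc1cc(OC[C@@H]2CN(C)c3ccccc3O2)cc(C)c1C(=O)Nc1cc(C2(C(=O)O)CC2)ccc1Cl` carries the change (1-carboxycyclopropyl in place of 1-carboxy-1-methylethyl on an aromatic carbon). Going by the values given here, no measured pair bears directly on closing 1-carboxy-1-methylethyl into 1-carboxycyclopropyl; the only measured step at this carbon, an 11-fold lower number from compound 1 to compound 3 (1.04 log units; beyond the scatter), concerns the branching itself, which compound 4 keeps. A change within the scatter, or at most a modest rise, is therefore expected. Compound 4 is estimated at 1.5 nM (range 0.4 nM to 6 nM), meaning an expected step of a 2.1-fold higher number from compound 3 to compound 4 (0.33 log units; beyond the scatter).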

Compound 4, half-maximal inhibitory concentration in the prostaglandin D2 receptor assay: 1 nM
For compound 4 the middle estimate is 1.5-fold (0.18 log units) above the measured one; the measured number falls inside the stated range.
By their numbers in the prostaglandin D2 receptor assay, from the lowest: compounds 3 and 4 (each within the scatter of the next); then compound 1; then compound 2.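

In the prostaglandin D2 receptor assay compound 4 gives 1 nM: closing the branched carbon into 1-carboxycyclopropyl is tolerated at this aromatic carbon, with a 1.4-fold higher number from compound 3 to compound 4 (0.15 log units; within the scatter), and the ring keeps the advantage of branching over carboxymethyl, with a 7.6-fold lower number from compound 1 to compound 4 (0.88 log units; beyond the scatter). In a physicochemical assay for solubility, measured as kinetic solubility (on this read-out higher numbers stand for higher solubility and lower numbers for lower solubility), compound 3 gives 490 ug/mL and compound 4 gives 321 ug/mL, and the same change stays within the scatter, with a 1.5-fold lower number from compound 3 to compound 4 (0.18 log units; within the scatter). No measurement available here explains these results. On these data alone, whether a larger 1-carboxycyclobutyl group, or a tetrazole in place of the carboxylic acid, would keep the number in the same range at this carbon remains open.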